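Ring substitution on the anilide of a thiazolidinedione series

A few compounds are considered here, and "the series" means these few. Any claim that something is new, unique, unknown or untested is made for them only; others in the source may bear on it.

Measured so far:
Compound 1 `Cc1cccc2sc(NC(=O)COc3ccc(/C=C4\SC(=O)NC4=O)cc3)nc12` gives 45800 nM in a functional assay on K562 cells (Homo sapiens) for inhibition; a higher number here means a weaker inhibitor of growth, a lower number a stronger inhibitor of growth.
Compound 2 `O=C(COc1ccc(/C=C2\SC(=O)NC2=O)cc1)Nc1ccc([N+](=O)[O-])cc1` gives 29500 nM in this assay.
Compound 3 `O=C(COc1ccc(/C=C2\SC(=O)NC2=O)cc1)Nc1ccccc1` gives 17600 nM in this assay.

Compound 3 has the lowest number of the three. Compound 2 lies close to it, and the step of a 1.7-fold lower number from compound 2 to compound 3 (0.22 log units; within the scatter) sits within the scatter, so the two cannot be told apart. Within the data shown here, compound 1 stands further away, with a gap to compound 3 that lies beyond the scatter; compound 1 differs from compound 3 in more than one place, so no single step is drawn between them.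

Compound 4 `Cc1ccc(NC(=O)COc2ccc(/C=C3\SC(=O)NC3=O)cc2)cc1Cl` has not yet been measured. It differs from compound 3 by 3-chloro-4-methylphenyl in place of phenyl on an amide-type nitrogen. Among the measured compounds shown here, the only step that bears on this change is the one from compound 2 to compound 3, also a substitution on the anilide ring, and that step stayed within the scatter. For compound 4 the expected step is therefore a 1.2-fold lower number from compound 3 to compound 4 (0.07 log units; within the scatter), no change beyond the scatter. Compound 4 is estimated at 15000 nM, with a range from 6000 nM to 40000 nM.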

Compound 4, concentration for 50% growth inhibition: 19600 nM
The estimate for compound 4 lay 1.3-fold (0.12 log units) below the measured number; the measured number falls inside the stated range.
By their numbers in this assay, from the lowest: compounds 3, 4, 2 and 1 (each within the scatter of the next, the first and the last beyond it).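

The chlorine and methyl of 3-chloro-4-methylphenyl give a result that cannot be told apart from plain phenyl in this assay (a 1.1-fold higher number from compound 3 to compound 4 (0.05 log units; within the scatter)). The same group also cannot be told apart from 4-nitrophenyl (a 1.5-fold lower number from compound 2 to compound 4 (0.18 log units; within the scatter)), so the three anilide rings shown, phenyl, 4-nitrophenyl and 3-chloro-4-methylphenyl, sit together at this place on the amide-type nitrogen. Nothing at hand accounts for this flat result.

The compounds shown leave open whether an amine or a carboxylic acid on the anilide ring, or a longer chain in place of that ring on the amide-type nitrogen, would move the number beyond the scatter. Compound 1 differs from compound 3 in more than one place, so the gap it shows cannot be assigned to any single change.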